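A Chloro Group Enters the Benzyl Arm of Compound 3

A few compounds are considered here, and "the series" means these few. Any claim that something is new, unique, unknown or untested is made for them only; others in the source may bear on it.

Of the compounds shown here, three sharing one core have been measured in a physicochemical assay for pharmacokinetics; a lower number here means that the compound disappears faster, a higher number that the compound lasts longer. Compound 1 `O=C(NCC1CCCCC1)N1C(=O)c2ccccc2S1(=O)=O` carries a cyclohexyl group; in this assay compound 1 reaches > 166 h, which is a limit of the assay rather than a number. Compound 2 `O=C(NCc1cccs1)N1C(=O)c2ccccc2S1(=O)=O` carries a thiophen-2-yl group, and in this assay compound 2 gives > 166 h, again a limit. Compound 3 `O=C(NCc1ccccc1)N1C(=O)c2ccccc2S1(=O)=O` carries a phenyl group; in this assay compound 3 gives > 166 h, also a limit. Compound 3 thus stands where every value shown stands, at the limit of > 166 h in this assay, at which 3 of the 3 values shown sit. The steps a step that the two limits leave unreadable from compound 1 to compound 3 and a step that the two limits leave unreadable from compound 2 to compound 3 cannot be read for size, since both ends of each sit at the limit.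

Compound 4 `O=C(NCc1ccccc1Cl)N1C(=O)c2ccccc2S1(=O)=O` differs from compound 3 as follows: chloro in place of hydrogen on an aromatic carbon. The chlorine enters on an aromatic carbon of the six-membered aromatic ring of carbon only. For the measured compounds named here, no measured step bears on this change with a readable size; all three steps among compounds 1, 2 and 3 are unreadable, and nothing among them points away from the limit. Compound 4 is therefore expected to remain at the limit, with the step that the limit leaves unreadable from compound 3 to compound 4 estimated as no change beyond the scatter. The estimate for compound 4 is 300 h, between 100 h and 1000 h.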

Compound 4, half-life: > 166 h
Compound 4: no number, only a limit (the forecaster's own chance of this, stated with the estimate: 85%); the middle value is on the limit's open side.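

In this assay compound 4 gives > 166 h, which is a limit and not a number. For the compounds shown here, no step from compound 1, compound 2 or compound 3 to compound 4 can be read for size: the limit of > 166 h in this assay, at which 4 of the 4 values shown sit. The compounds shown leave open how long each lasts past that limit, and whether the chloro group alters it at all.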